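Adding a diethylamino group to compound 2

The source may report more compounds than this note shows. Statements on the series, on what has been measured and on what is new or still open speak of the compounds shown alone.

Values in an ADME assay on Vero cells (Chlorocebus sabaeus) for cytotoxicity, read by resazurin assay, with a stated time of 3 days (a lower number here means a stronger inhibitor, a higher number a weaker inhibitor), for the measured compounds, each one a limit of the assay and not a number:
compound 1 `CCCCOC(=O)Nc1cc2nc(C3CCCCC3)[nH]c2cc1N(C)C` gives > 100 ug/mL as a limit
compound 2 `CCCCOC(=O)Nc1cc2nc(C3CCCCC3)[nH]c2cc1N(CC)CC` gives > 100 ug/mL as a limit
compound 3 `CCOCCOC(=O)Nc1cc2nc(C3CCCCC3)[nH]c2cc1N(CC)CC` gives > 100 ug/mL as a limit

Compound 2 has only a limit (> 100 ug/mL) and no number. Among the measured compounds shown here, the series as measured offers no number either, with the limit of > 100 ug/mL in this assay, at which 3 of the 3 values shown sit, as the whole of the evidence in this assay so far.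

Compound 4 `CCCCOC(=O)Nc1cc2nc(C3CCCCC3)[nH]c2cc1N(CC)CCN(CC)CC` is compound 2 with one change on the side of the aromatic nitrogen, diethylamino in place of hydrogen on a saturated chain carbon, two bonds along the chain from a nitrogen on an aromatic ring as the difference, so that one ethyl becomes 2-(diethylamino)ethyl.

For the measured compounds named here, two measured steps bear on this. The step that the two limits leave unreadable from compound 1 to compound 2 concerns the same amino group, and the step that the two limits leave unreadable from compound 2 to compound 3 concerns the other chain. Neither gives a size, so the expectation rests on judgement of the structural change and not on a measured step.

With the starting point only a limit, the expected change is an at least 2.0-fold lower number from compound 2 to compound 4 (0.30 log units; that floor lies within the scatter) toward a lower number, a loose estimate in which a further limit remains quite possible. Compound 4 is estimated at 50 ug/mL with 12 ug/mL to 150 ug/mL as the expected range.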

Compound 4, half-maximal inhibitory concentration: > 50 ug/mL
Compound 4 ended at the assay's limit; the forecaster's own chance of this, stated with the estimate: 35%; the middle value lies on the limit itself.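

In this assay compound 4 gives > 50 ug/mL, a limit and not a number. Compound 2 gives > 100 ug/mL, also a limit. No size can be read for the step to compound 4 from compound 1 or from compound 2. On these data alone, whether ethyl to 2-(diethylamino)ethyl moves the value in this assay at all, and in which direction, stays open.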